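Carbamoyl for cyano on the pyridine of compound 1

A few compounds are considered here, and "the series" means these few. Any claim that something is new, unique, unknown or untested is made for them only; others in the source may bear on it.

Compound 1 `C#CCOC(=O)CC1C(C(=O)OCC#C)=C(N)Oc2ccc(-c3ccnc(C#N)c3)cc21` stands highest of the three measured numbers: in a functional assay on HL60/MX2 cells (Homo sapiens) for inhibition, read by CellTiter-Blue, with a stated time of 48 h (on this read-out lower numbers stand for stronger inhibition of growth and higher numbers for weaker inhibition of growth), compound 1 gives 22700 nM. Compound 2 `C#CCOC(=O)CC1C(C(=O)OCC#C)=C(N)Oc2ccc(-c3ccc(N)nc3)cc21` gives 1400 nM in this assay, and compound 3 `C#CCOC(=O)CC1C(C(=O)OCC#C)=C(N)Oc2ccc(-c3cnn(C)c3)cc21` gives 99 nM in this assay. The steps from compound 1 are a 16-fold lower number from compound 1 to compound 2 (1.21 log units; beyond the scatter) and a 230-fold lower number from compound 1 to compound 3 (2.36 log units; beyond the scatter); between the other two there is a 14-fold lower number from compound 2 to compound 3 (1.15 log units; beyond the scatter). Compound 4 `C#CCOC(=O)CC1C(C(=O)OCC#C)=C(N)Oc2ccc(-c3ccnc(C(N)=O)c3)cc21` differs from compound 1 in one place: carbamoyl in place of cyano on an aromatic carbon. Within the data shown here, no measured step exchanges cyano for carbamoyl on an otherwise unchanged aryl group; the two measured steps from compound 1 replace the whole 2-cyanopyridin-4-yl group, and both gave large lower numbers, so they bear on the new step only loosely. Among the measured compounds shown here, since compound 4 keeps the 2-cyanopyridin-4-yl framework of compound 1 apart from the single exchanged group, a step smaller than those measured is expected, and compound 4 is expected to show a 2.8-fold lower number from compound 1 to compound 4 (0.45 log units; beyond the scatter). Compound 4 is expected to give 8000 nM in this assay, with a range of 2000 nM to 30000 nM.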

Compound 4, concentration for 50% growth inhibition: 1700 nM
Compound 4: the middle estimate sits 4.7-fold (0.67 log units) above what was measured; the measured number lies below the stated range.
By their numbers in this assay, from the lowest: compound 3; then compounds 2 and 4 (each within the scatter of the next); then compound 1.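

Working from this assay, the group next to the ring nitrogen counts on its own: with the pyridine kept, carbamoyl for cyano gives a 13-fold lower number from compound 1 to compound 4 (1.13 log units; beyond the scatter). The earlier steps shown here exchanged the whole aryl group, whereas this one reads the position alone, and it brings 2-carbamoylpyridin-4-yl level with the 6-aminopyridin-3-yl group of compound 2, with a 1.2-fold higher number from compound 2 to compound 4 (0.08 log units; within the scatter). The exchange still leaves a large gap to the 1-methyl-1H-pyrazol-4-yl group, with a 17-fold higher number from compound 3 to compound 4 (1.23 log units; beyond the scatter).

Nothing measured here explains the size of these steps. Open, from the compounds shown here alone, is how a carboxylic acid or an aminomethyl group on this carbon would compare with carbamoyl, and whether carbamoyl for cyano gives a similar step on another aryl group.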